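The source may report more compounds than this note shows. Statements on the series, on what has been measured and on what is new or still open speak of the compounds shown alone.

Measured in an ADME assay on NIH3T3 cells (Mus musculus) for inhibition, read by MTT assay, with a stated time of 48 h; on this read-out lower numbers stand for stronger inhibition and higher numbers for weaker inhibition:
Compound 1 `CCc1ccc(-c2nc3ccccn3c2Sc2ccccc2)cc1`: > 100000 nM (a limit)
Compound 2 `COc1ccc(-c2nc3ccccn3c2Sc2ccccc2)cc1`: 91700 nM
Compound 3 `Clc1ccc(-c2nc3ccccn3c2Sc2ccccc2)cc1`: > 100000 nM (a limit)

Compound 3 is known only as a limit, > 100000 nM. The series as a whole shows (the limit of > 100000 nM in this assay, at which 2 of the 3 values shown sit). Compound 4 `c1ccc(Sc2c(-c3ccsc3)nc3ccccn23)cc1` carries thiophen-3-yl in place of 4-chlorophenyl on an aromatic carbon. The nearest evidence comes from the other exchanges at this carbon. These are an at least 1.0-fold lower number from compound 1 to compound 2 (0.03 log units; that floor lies within the scatter) and an at least 1.0-fold higher number from compound 2 to compound 3 (0.03 log units; that floor lies within the scatter), while a step that the two limits leave unreadable from compound 1 to compound 3 gives no size. None shows a step beyond the scatter, so none beyond the scatter is expected in this assay, and no direction is favoured. A report as a limit alone is quite likely. The expected change is a number no higher from compound 3 to compound 4 (the limit leaves the size open). Compound 4 is estimated at 100000 nM, with an expected range of 45000 nM to 200000 nM.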

Compound 4, half-maximal inhibitory concentration: 94100 nM
Compound 4: middle estimate off by 1.1-fold (0.03 log units), on the high side, and the stated range covers the measured number.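

Among these compounds, with thiophen-3-yl at this carbon, the change from a six-membered aromatic ring of carbon only to a five-membered aromatic ring with 1 hetero atom produces no step beyond the scatter in this assay: the one step between two numbers is a 1.0-fold higher number from compound 2 to compound 4 (0.01 log units; within the scatter). The other two steps give only floors, an at least 1.0-fold lower number from compound 3 to compound 4 (0.02 log units; that floor lies within the scatter) and an at least 1.0-fold lower number from compound 1 to compound 4 (0.02 log units; that floor lies within the scatter). Much of the series stays bounded rather than measured: the limit of > 100000 nM in this assay, at which 2 of the 4 values shown sit.

The compounds shown leave open whether an amine or a carboxylic acid at this carbon would give a step beyond the scatter. They also leave open what such groups would do on the phenylsulfanyl group.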